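Dimethylamino in Place of Methoxy on a Shared Core

The source may report more compounds than this note shows. Statements on the series, on what has been measured and on what is new or still open speak of the compounds shown alone.

Among the compounds with values here, compound 1 `COc1ccc(/C=C2\CCC/C(=C\c3ccc([N+](=O)[O-])cc3)C2=O)cc1` has the higher of the two numbers so far recorded in a functional assay on MOLT-4 cells (Homo sapiens) for cytotoxicity, with a stated time of 72 h; a higher number here means a weaker inhibitor, a lower number a stronger inhibitor: compound 1 gives 300000 nM. The other measured compound, compound 2 `O=C1/C(=C/c2ccc(F)cc2)CCC/C1=C\c1ccccc1[N+](=O)[O-]`, differs from compound 1 in more than one place; in this assay compound 2 gives 1870 nM, a much lower number. Compound 3 `CN(C)c1ccc(/C=C2\CCC/C(=C\c3ccc([N+](=O)[O-])cc3)C2=O)cc1` remains unmeasured. It differs from compound 1 in a single place: dimethylamino in place of methoxy on an aromatic carbon. Within the data shown here, no pair of measured compounds shows this particular change, so its size cannot be read from the data. The step from compound 1 to compound 3 is expected to be a moderate move toward a lower number, by a 5.0-fold lower number from compound 1 to compound 3 (0.70 log units; beyond the scatter), though a change within the scatter cannot be excluded. Compound 3 is therefore estimated to give 60000 nM in this assay, with a range from 6000 nM to 300000 nM.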

Compound 3, half-maximal inhibitory concentration: > 500000 nM
Compound 3 gave a limit, no number; the forecaster's own chance of this, stated with the estimate: 25%; at least 8.3-fold (0.92 log units) between middle value and limit.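

Compound 3 stands only as a limit in this assay, not as a number: the limit of > 500000 nM in this assay, at which 1 of the 3 values shown sits. Dimethylamino in place of methoxy on an aromatic carbon, para to a large group, brings an at least 1.6-fold higher number from compound 1 to compound 3 (0.22 log units; that floor lies within the scatter). Within the data shown here, this is the first reading of a change at this position, and it gives no sign of the move toward a lower number on the shared core, though with the floor inside the scatter the true distance between the two compounds stays unfixed.

The compounds shown leave open how far compound 3 lies beyond its limit, and whether a hydroxyl or a primary amine in this place would give a lower number than methoxy. They also leave open whether 4-methoxyphenyl to 4-(dimethylamino)phenyl would read the same way on another core.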